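Removing a Methyl from a Non-Cytotoxic Thiazole Analogue

The source may report more compounds than this note shows. Statements on the series, on what has been measured and on what is new or still open speak of the compounds shown alone.

Two measured compounds share one core. Compound 1 `CCOS(=O)(=O)/C=C/c1ccc(OCc2ccccc2)cc1OCCc1nc(-c2ccccc2)oc1C` carries a 5-methyl-2-phenyl-1,3-oxazol-4-yl group, and compound 2 `CCOS(=O)(=O)/C=C/c1ccc(OCc2ccccc2)cc1OCCc1nc(-c2ccccc2)sc1C` carries a 5-methyl-2-phenyl-1,3-thiazol-4-yl group in its place. In an ADME assay on COS-7 cells (Chlorocebus aethiops) for cytotoxicity, read by MTT assay, with a stated time of 48 h (a higher number here means a weaker inhibitor, a lower number a stronger inhibitor), compound 1 gives > 100000 nM, which is a limit of the assay rather than a number. In this assay compound 2 gives > 100000 nM, again a limit and not a number. The step that the two limits leave unreadable from compound 1 to compound 2 therefore cannot be sized. Compound 2 stands where every measured value sits, namely (the limit of > 100000 nM in this assay, at which 2 of the 2 values shown sit). Compound 3 `CCOS(=O)(=O)/C=C/c1ccc(OCc2ccccc2)cc1OCCc1csc(-c2ccccc2)n1` differs from compound 2 by one change, (hydrogen in place of methyl on an aromatic carbon), hydrogen in place of methyl on an aromatic carbon. Among the compounds with values here, only the step from compound 1 to compound 2 bears on this, and it is unreadable, so no direction or size beyond the scatter can be drawn. The expected step that the limit leaves unreadable from compound 2 to compound 3 is estimated as flat. Compound 3 is expected to give about 150000 nM, within a range from 50000 nM to 500000 nM, most likely again reported as a limit.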

Compound 3, half-maximal inhibitory concentration: > 100000 nM
Compound 3: a limit, no number; the forecaster's own chance of this, stated with the estimate: 90%; the middle value does not contradict the limit.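

In this assay compound 3 gives > 100000 nM as a limit and not a number. Within the data shown here, no step among compound 1, compound 2 and compound 3 can be read, as all three share one limit: (the limit of > 100000 nM in this assay, at which 3 of the 3 values shown sit). Going by these compounds, whether removing the methyl or exchanging 5-methyl-2-phenyl-1,3-oxazol-4-yl for 5-methyl-2-phenyl-1,3-thiazol-4-yl changes the read-out at all stays open.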